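Piperazine substituent swaps on an aminothiophene ketone core

This account rests on a few compounds, and the source may have more. Where it says the series, first, only, none or still open, it means among the compounds named here.

Measured compounds:
compound 1 `Nc1scc(CN2CCN(C3CCCCCC3)CC2)c1C(=O)c1ccc(Cl)cc1` gives 0% in an assay on CHO cells for displacement of a labelled ligand from adenosine receptor A3 (Homo sapiens), read by scintillation counting, with a stated time of 120 min, tested at 10 uM; a lower number here means less inhibition, a higher number more inhibition at the concentration tested (going by the name of the read-out)
compound 2 `Nc1scc(CN2CCN(CCCc3ccc(Cl)cc3)CC2)c1C(=O)c1ccc(Cl)cc1` gives 0% in this assay

Compound 2 stands level with compound 1 in this assay: the step of no change at the digits printed from compound 1 to compound 2 (within the scatter) shows that exchanging the group on the ring nitrogen left the read-out unchanged. Compound 3 `Nc1scc(CN2CCN(c3ccccc3Cl)CC2)c1C(=O)c1ccc(Cl)cc1` has not yet been measured. It differs from compound 2 in one place: 2-chlorophenyl in place of 3-(4-chlorophenyl)propyl on an amine nitrogen in a ring. Among the compounds with values here, the only step that bears on this change is the one from compound 1 to compound 2, which was within the scatter; it also touched the same ring nitrogen and gave no change at all. Nothing in the two measured compounds points to inhibition rising when yet another group is put on that nitrogen. The author therefore expects a step of a number 3 percentage points higher from compound 2 to compound 3 (within the scatter), which is none beyond the scatter. For compound 3 the estimate is 3%, with a range from -8% to 18%.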

Compound 3, a percentage reported as inhibition, at one concentration (the size of the read-out at that concentration, not a potency): 0%
For compound 3 the middle estimate is 3 percentage points above the measured one, within the range that was stated.
By their numbers in this assay, from the lowest: compounds 1, 2 and 3 (each within the scatter of the next).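

In this assay the read-out shows no change at the digits printed from compound 2 to compound 3 (within the scatter) with 2-chlorophenyl in place of 3-(4-chlorophenyl)propyl and no change at the digits printed from compound 1 to compound 3 (within the scatter) with 2-chlorophenyl in place of cycloheptyl on the amine nitrogen in the ring. That nitrogen has now carried three different groups, including an aromatic ring with no propyl chain, and all three stand level, so no group tried there has moved the read-out. No measurement at hand offers an explanation for this flat result.

Going by these compounds, whether a chain ending in a carboxylic acid or a primary amine, or an acetyl group on that nitrogen, would give any inhibition remains open. So does the effect of changes away from this nitrogen, such as a methoxy group in place of the chlorine on the ketone's aromatic ring.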